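The compounds below may be only part of what the source reports. "The series", "measured", "known", "first", "only" and "open" are said of these compounds alone.

Measured so far:
- compound 1, `CC1=C(N2CC2)C(=O)C(CC(C)OC(N)=O)=C(N2CC2)C1=O`: 5.86
- compound 2, `COCCC1=C(N2CC2)C(=O)C(CCOC)=C(N2CC2)C1=O`: 5.18

In a functional assay on L1210 cells (Mus musculus), with a stated time of 1 days (a lower number here means a less potent compound, a higher number a more potent compound, by a factor of ten per unit of this negative logarithm), compound 1 gives 5.86, while compound 2 gives 5.18. Compound 1 therefore stands highest of the two, and its gap to compound 2 lies beyond the usual scatter of repeated measurements.

Compound 3, `CC1=C(N2CC2)C(=O)C(N2CC2)=C(N2CC2)C1=O`, has not yet been tested in this assay. It differs from compound 1 in a single place: a group of 3 heavy atoms (2 carbon, 1 nitrogen; one three-membered non-aromatic ring with 1 hetero atom) in place of a group of 7 heavy atoms (4 carbon, 1 nitrogen, 2 oxygen; no ring), on a double-bonded ring carbon. Within the data shown here, no pair of measured compounds shows this same change, so its size cannot be read from a comparison already in hand. Compound 1 carries two aziridin-1-yl groups on the shared core, and in compound 3 a third aziridin-1-yl enters where the open chain stood. An upward step in this assay is expected, and compound 3 is estimated at 6.7, with a range from 5.8 to 7.6. That estimate means an expected step of a number 0.84 log units higher from compound 1 to compound 3 (beyond the scatter), beyond the scatter.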

Compound 3, logarithm of the reciprocal of the active concentration, log(1/C): 6.54
Beside the measured number, compound 3's estimate is 0.16 log units above it; the range from low to high includes it.
By their numbers in this assay, from the lowest: compound 2; then compound 1; then compound 3.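

In this assay, replacing the open chain of 7 heavy atoms on a double-bonded ring carbon with an aziridin-1-yl group gives a number 0.68 log units higher from compound 1 to compound 3 (beyond the scatter). The chain and its hydrogen-bond donor are therefore not needed for activity at this position, and the smaller ring-bearing group does better here than the chain does. Nothing available explains why the number rises.

This single swap changes the group's size, adds a three-membered ring and removes the hydrogen-bond donor all at once, so these changes cannot be told apart. As far as these compounds go, it remains open whether a primary amine, a methyl group or a plain ethyl chain at this ring carbon would match the aziridin-1-yl group, or whether the three-membered ring itself is what counts.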